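Trifluoromethoxy for trifluoromethyl: step from compound 2 to 3

A few compounds are considered here, and "the series" means these few. Any claim that something is new, unique, unknown or untested is made for them only; others in the source may bear on it.

For the measured compounds named here, in a functional assay on the whole organism (aorta) with Rattus norvegicus as the target (on this read-out lower numbers stand for smaller maximal responses and higher numbers for larger maximal responses), compound 2 `O=C1C(Nc2ccc(C(F)(F)F)cc2)=CC(=O)c2ncccc21` gives 91%, the higher of the two numbers measured so far; compound 1 `O=C1C(Nc2ccc(F)cc2)=CC(=O)c2ncccc21` gives 79%, and the step is a number 12 percentage points higher from compound 1 to compound 2 (beyond the scatter). Compound 3 `O=C1C(Nc2ccc(OC(F)(F)F)cc2)=CC(=O)c2ncccc21` differs from compound 2 by trifluoromethoxy in place of trifluoromethyl on an aromatic carbon. Going by the values given here, no measured step exchanges these two groups; the single step measured, a number 12 percentage points higher from compound 1 to compound 2 (beyond the scatter), concerns a different pair of groups at the same place and bears on the present change only loosely. The change to compound 3 is therefore expected to stay within the scatter, a number 2 percentage points lower from compound 2 to compound 3 (within the scatter). Compound 3 is estimated at 89%, within a range from 76% to 100%.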

Compound 3, largest response reached (Emax), in percent of the reference or control that the assay uses: 88%
Estimate against measurement, compound 3: 1 percentage points above; the range from low to high includes it.
By their numbers in this assay, from the lowest: compounds 1, 3 and 2 (each within the scatter of the next, the first and the last beyond it).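

In this assay, trifluoromethoxy on this aromatic carbon, para to a large group, cannot be told apart from trifluoromethyl (a number 3 percentage points lower from compound 2 to compound 3 (within the scatter)), so the added oxygen and its hydrogen-bond acceptor leave no readable mark on the maximal response. It also cannot be told apart from fluoro (a number 9 percentage points higher from compound 1 to compound 3 (within the scatter)), although fluoro and trifluoromethyl themselves lie beyond the scatter of each other. No measurement on hand accounts for these readings. Going by these compounds, whether an amine or a carboxylic acid at this place would keep the response remains open. A longer chain is equally untested ground here.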